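The source may hold more compounds than are shown below. What is called first, only, known or untested is meant among the compounds shown, and "the series" means these compounds.

Measured so far:
compound 1 `CC(O)CSc1nc(NCc2ccc(-c3ccccn3)cc2)c2[nH]nc(C(C)C)c2n1` — 62 nM
compound 2 `CC(C)c1n[nH]c2c(NCc3ccc(-c4ccccn4)cc3)nc(SCC(C)(C)O)nc12` — 507 nM
compound 3 `CSCCSc1nc(NCc2ccc(-c3ccccn3)cc2)c2[nH]nc(C(C)C)c2n1` — 975 nM

All three numbers come from a functional assay on HT cells (Homo sapiens) for antiproliferative activity, read by fluorescence, with a stated time of 72 h; on this read-out higher numbers stand for weaker inhibition of growth and lower numbers for stronger inhibition of growth. Compound 2 stands second highest of the three: its nearest neighbour is compound 3, at a 1.9-fold higher number from compound 2 to compound 3 (0.28 log units; within the scatter), while compound 1 lies well apart, at an 8.2-fold higher number from compound 1 to compound 2 (0.91 log units; beyond the scatter).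

Compound 4 `C=CCSc1nc(NCc2ccc(-c3ccccn3)cc2)c2[nH]nc(C(C)C)c2n1` is not yet measured. Against compound 2 the change is vinyl in place of 1-hydroxy-1-methylethyl on a saturated chain carbon bound to a sulfur. Among the compounds with values here, two measured steps bear on it. Giving up the hydroxyl-bearing group for one with no hydrogen-bond donor or acceptor has already been seen in a 1.9-fold higher number from compound 2 to compound 3 (0.28 log units; within the scatter), which stayed within the scatter; the same loss starting from compound 1 gave a 16-fold higher number from compound 1 to compound 3 (1.20 log units; beyond the scatter). Within the data shown here, no measured compound carries a double bond outside aromatic rings, so that part of the change has no measured counterpart. The expectation in this assay is therefore a small rise or nothing beyond the scatter, a 1.6-fold higher number from compound 2 to compound 4 (0.20 log units; within the scatter). Compound 4 is estimated at 800 nM, expected to fall between 250 nM and 2500 nM.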

Compound 4, concentration for 50% growth inhibition: 1010 nM
The estimate for compound 4 lay 1.3-fold (0.10 log units) below the measured number; the measured number falls inside the stated range.
By their numbers in this assay, from the lowest: compound 1; then compounds 2, 3 and 4 (each within the scatter of the next).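

In this assay, replacing the (methylsulfanyl)methyl group with vinyl on the saturated chain carbon bound to a sulfur changes nothing beyond the scatter (a 1.0-fold higher number from compound 3 to compound 4 (0.02 log units; within the scatter)), so two different chains without a hydroxyl read alike. Losing the hydroxyl from the 1-hydroxy-1-methylethyl group also stays within the scatter (a 2.0-fold higher number from compound 2 to compound 4 (0.30 log units; within the scatter)), while the large gap to the 1-hydroxyethyl group recurs (a 16-fold higher number from compound 1 to compound 4 (1.21 log units; beyond the scatter)), leaving that chain alone apart from the other three and showing that a hydroxyl by itself does not set it apart, as the hydroxyl-bearing compound 2 goes against any such pattern. No measurement here accounts for this difference.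

The compounds shown leave open whether the gap belongs specifically to the 1-hydroxyethyl group. Hydroxymethyl, a longer hydroxyalkyl chain, an amine or a carboxylic acid at this place could test that.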